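Aryl swap on the shared core: compound 2 to compound 4

The source may report more compounds than this note shows. Statements on the series, on what has been measured and on what is new or still open speak of the compounds shown alone.

Compound 1 `COc1ccccc1C1CC(c2cc(OC)c(OC)c(OC)c2)=NN1C(C)=O` is the anchor of the series in a functional assay on L1210 cells (Mus musculus) for cytotoxicity, read by MTT assay, with a stated time of 72 h; a higher number here means a weaker inhibitor, a lower number a stronger inhibitor; compound 1 gives 43000 nM. Compound 3 `COc1ccc(C2CC(c3cc(OC)c(OC)c(OC)c3)=NN2)cc1OC` differs from compound 1 in several places. In this assay compound 3 gives 42000 nM, a value within the scatter of compound 1. Compound 2 `COc1ccc(OC)c(C2CC(c3cc(OC)c(OC)c(OC)c3)=NN2C(C)=O)c1` reaches only > 100000 nM in this assay, which is a limit of the assay and not a number. For the measured compounds named here, the one step that leads onto compound 2, an at least 2.3-fold higher number from compound 1 to compound 2 (0.36 log units; beyond the scatter), is therefore known only as a lower bound, which rests on (the limit of > 100000 nM in this assay, at which 1 of the 3 values shown sits).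

Compound 4 `COc1ccc(C2CC(c3cc(OC)c(OC)c(OC)c3)=NN2C(C)=O)cc1O` has not yet been measured. The change from compound 2 is 3-hydroxy-4-methoxyphenyl in place of 2,5-dimethoxyphenyl on a saturated ring carbon. Going by the values given here, only the step from compound 1 to compound 2 bears on this change, and it shows that adding a methoxy on the aromatic carbon pushed the number up beyond the scatter and out of range. Compound 4 carries the acetyl group of compound 1 and compound 2 with a different aryl pattern; compound 1 and compound 3 both sit near the same number. Compound 4 is expected at 40000 nM, within 15000 nM to 120000 nM. The step of an at least 2.5-fold lower number from compound 2 to compound 4 (0.39 log units; beyond the scatter) is thus expected to bring compound 4 back down off the limit.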

Compound 4, half-maximal inhibitory concentration: > 100000 nM
Compound 4: only a limit was reported (the forecaster's own chance of this, stated with the estimate: 25%); middle value at least 2.5-fold (0.39 log units) from the limit.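

Compound 4 gives > 100000 nM in this assay, which is a limit of the assay and not a number, so a second aryl pattern on the saturated ring carbon of the shared core ends off scale, as compound 2 does. The change to 3-hydroxy-4-methoxyphenyl in place of 2-methoxyphenyl gives an at least 2.3-fold higher number from compound 1 to compound 4 (0.36 log units; beyond the scatter), so the upward move from compound 1 is not confined to the 2,5-dimethoxyphenyl pattern, and compound 1 is the only acetyl compound shown that still has a readable value. The step between compound 2 and compound 4 cannot be read, so no order can be given for these two aryl groups, and the series now presses against the top of the range: the limit of > 100000 nM in this assay, at which 2 of the 4 values shown sit.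

No pair shown isolates the acetyl group on the ring nitrogen, as compound 3 differs from compound 1 in several places. Also open, going by these compounds, is how an amine or a carboxylic acid on the aryl ring would read, and whether any aryl pattern on this carbon can bring the number below that of compound 1.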